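A few compounds are considered here, and "the series" means these few. Any claim that something is new, unique, unknown or untested is made for them only; others in the source may bear on it.

Measured so far:
compound 1, `CN(C)c1ccc(/C=C2\CCC/C(=C\c3ccccc3[N+](=O)[O-])C2=O)cc1`: 164000 nM
compound 2, `COc1ccc(/C=C2\CCC/C(=C\c3ccccc3[N+](=O)[O-])C2=O)cc1`: 42400 nM
compound 3, `CN(C)c1ccc(/C=C2\CCC/C(=C\c3cccc([N+](=O)[O-])c3)C2=O)cc1`: 156000 nM

These three compounds were tested in a functional assay on L1210 cells (Mus musculus) for cytotoxicity, with a stated time of 48 h; a lower number here means a stronger inhibitor, a higher number a weaker inhibitor. Compound 4, `COc1ccc(/C=C2\CCC/C(=C\c3cccc([N+](=O)[O-])c3)C2=O)cc1`, has not yet been measured. It differs from compound 3 in one place: methoxy in place of dimethylamino on an aromatic carbon. The same change, in the same place, links compound 1 to compound 2: methoxy in place of dimethylamino on an aromatic carbon. There it gave a 3.9-fold lower number from compound 1 to compound 2 (0.59 log units; beyond the scatter). The cores of compound 1 and compound 3 differ in how the same atoms are joined: 3-nitrophenyl in place of 2-nitrophenyl on a double-bonded chain carbon bound to a double-bonded ring carbon. That change gave a 1.1-fold lower number from compound 1 to compound 3 (0.02 log units; within the scatter), so the two cores sit close together as far as these numbers show.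

Among the measured compounds shown here, compound 3 gives 156000 nM, within the scatter of compound 1, and the same change made a 3.9-fold lower number from compound 1 to compound 2 (0.59 log units; beyond the scatter); on those two facts rests the expectation of a step of similar size, kept wide since only one example of the change exists so far. The step from compound 3 to compound 4 is expected to be about a 3.9-fold lower number from compound 3 to compound 4 (0.59 log units; beyond the scatter). Compound 4 is expected to give 40000 nM, between 20000 nM and 80000 nM.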

Compound 4, half-maximal inhibitory concentration: 29500 nM
For compound 4 the middle estimate is 1.4-fold (0.13 log units) above the measured one, and the stated range covers the measured number.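

In this assay, putting 4-methoxyphenyl in place of 4-(dimethylamino)phenyl again gives a lower number, with a 5.3-fold lower number from compound 3 to compound 4 (0.72 log units; beyond the scatter). Set beside the earlier case, the change carries over from the core of compound 1 to the core of compound 3 with a step of much the same size: the same change on two cores in this assay, a 3.9-fold lower number (0.59 log units; beyond the scatter) from compound 1 to compound 2 and a 5.3-fold lower number (0.72 log units; beyond the scatter) from compound 3 to compound 4, 1.4-fold (0.14 log units) apart, within the scatter of two such steps. Among the compounds shown here, this shows that the step held on two closely related cores, one with a 2-nitrophenyl group and one with a 3-nitrophenyl group, but with only two examples in one kind of cell it does not show that the step would hold on other cores, nor why the number falls.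

The compounds shown leave open whether a different group in the same place, such as a hydroxyl, a primary amine or a longer ether like ethoxy, would give a lower number than methoxy. They also leave open whether the step survives on a core whose other ring is a plain phenyl without the nitro group.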